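Sulfonate aryl exchange in a coumarin-free note series

The compounds below may be only part of what the source reports. "The series", "measured", "known", "first", "only" and "open" are said of these compounds alone.

Measured compounds:
compound 1 `Cc1ccc2nc(SCc3cc(=O)oc4cc(OS(=O)(=O)c5ccccc5[N+](=O)[O-])ccc34)[nH]c(=O)c2c1` — 107000 nM
compound 2 `O=C1CCN=C(SCc2cc(=O)oc3cc(OS(=O)(=O)c4ccc(F)cc4)ccc23)N1` — 111000 nM

In an ADME assay on Vero cells (Chlorocebus sabaeus) for cytotoxicity, read by polymerase chain reaction, with a stated time of 18 h (on this read-out higher numbers stand for lower toxicity in this test and lower numbers for higher toxicity in this test), compound 2 gives 111000 nM, the higher of the two numbers recorded so far; compound 1, in the same assay, gives 107000 nM, and the two values lie within the scatter of each other, so no order between them is claimed. Within the data shown here, compound 1 and compound 2 differ in more than one place, and no single step connects them.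

Compound 3 `O=C1CCN=C(SCc2cc(=O)oc3cc(OS(=O)(=O)c4ccccc4[N+](=O)[O-])ccc23)N1` is not yet measured. It differs from compound 2 in one place: 2-nitrophenyl in place of 4-fluorophenyl on a sulfonyl sulfur. The group that enters is the same one carried by compound 1 on its sulfonyl sulfur. Because compound 1 gives 107000 nM and compound 2 gives 111000 nM, the expected step of a 1.1-fold lower number from compound 2 to compound 3 (0.02 log units; within the scatter) is none beyond the scatter. For compound 3 the estimated value is 105000 nM, with a range from 55000 nM to 200000 nM.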

Compound 3, half-maximal cytotoxic concentration: 75200 nM
The estimate for compound 3 lay 1.4-fold (0.14 log units) above the measured number; the range from low to high includes it.
By their numbers in this assay, from the lowest: compounds 3, 1 and 2 (each within the scatter of the next).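

In this assay, 2-nitrophenyl in place of 4-fluorophenyl on a sulfonyl sulfur gives a 1.5-fold lower number from compound 2 to compound 3 (0.17 log units; within the scatter) and so does not separate these two groups at this position. Among these compounds, with 2-nitrophenyl held constant, the first single-place comparison of the groups on the other sulfur gives a 1.4-fold lower number from compound 1 to compound 3 (0.15 log units; within the scatter) and leaves the group of 7 heavy atoms and the group of 12 heavy atoms equally unseparated. Thus, neither single change shown moves the read-out beyond the scatter in this small set. Nothing available bears on what underlies either step.

As far as these compounds go, whether a small alkyl group such as methyl on the sulfonyl sulfur would give a step beyond the scatter remains open. The same question stands for an aryl ring carrying an amine or a carboxylic acid.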